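A few compounds are considered here, and "the series" means these few. Any claim that something is new, unique, unknown or untested is made for them only; others in the source may bear on it.

Working notes on the series. In a functional assay on the whole organism for inhibition, with Rattus norvegicus as the target, read by paw edema, with stated times of 30 min and 5 h, at a dose of 0.28 mmol/kg by the oral route (a higher number here means more inhibition at the dose given (going by the name of the read-out), a lower number less inhibition), compound 1 `CNC(=O)c1nc(-c2cc(OC)c(OC)c(OC)c2)n(-c2ccc(OC)cc2)n1` gives 50%, compound 2 `CCNC(=O)c1nc(-c2cc(OC)c(OC)c(OC)c2)n(-c2ccc(OC)cc2)n1` gives 52%, and compound 3 `COc1ccc(-n2nc(C(=O)Nc3ccccc3C)nc2-c2cc(OC)c(OC)c(OC)c2)cc1` gives 47%. Compound 3 sits at the lowest of the three numbers shown, but the gaps are a number 3 percentage points lower from compound 1 to compound 3 (within the scatter) and a number 5 percentage points lower from compound 2 to compound 3 (within the scatter), both within the scatter, as is a number 2 percentage points higher from compound 1 to compound 2 (within the scatter); the three compounds are not separated by these data. Compound 4 `COc1ccc(-n2nc(C(=O)Nc3ccccc3)nc2-c2cc(OC)c(OC)c(OC)c2)cc1` is not yet measured. It differs from compound 3 by hydrogen in place of methyl on an aromatic carbon, the methyl leaving an aromatic carbon of the six-membered aromatic ring of carbon only. Among the compounds with values here, no measured step touches that ring; the steps that exist exchange the whole group on the amide-type nitrogen, from methyl or ethyl to 2-methylphenyl, and every one of them stays within the scatter. For compound 4 the expected step is a number 1 percentage points higher from compound 3 to compound 4 (within the scatter), with no direction beyond the scatter. In this assay compound 4 is therefore estimated at 48%, between 35% and 60%.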

Compound 4, a percentage reported as inhibition, in the whole organism at one dose (the size of the read-out at that dose, not a potency): 46%
Estimate against measurement, compound 4: 2 percentage points above; the range from low to high includes it.
By their numbers in this assay, from the lowest: compounds 4, 3, 1 and 2 (each within the scatter of the next).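

Within the data shown here, in (this assay), this is the first step that touches the aromatic ring itself: phenyl with hydrogen in place of the methyl of 2-methylphenyl gives (a number 1 percentage points lower from compound 3 to compound 4 (within the scatter)), so the methyl on this aromatic carbon, ortho to a large group, has no readable effect on the number. Phenyl in place of the small chains on the amide-type nitrogen also stays within the scatter (a number 4 percentage points lower from compound 1 to compound 4 (within the scatter); a number 6 percentage points lower from compound 2 to compound 4 (within the scatter)), so methyl, ethyl, phenyl and 2-methylphenyl at this nitrogen are not separated at this single dose. No measurement shown bears on why these numbers stay together.

Open, from the compounds shown here alone, is whether a carboxylic acid or an amine on this phenyl ring, or a longer chain carrying an amine on the amide-type nitrogen, would move the number beyond the scatter. Also open, going by these compounds, is whether these compounds would separate at other doses.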